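Moving the halogen on the aryl ketone of compound 3

The source may report more compounds than this note shows. Statements on the series, on what has been measured and on what is new or still open speak of the compounds shown alone.

Compound 1 `N=C(N)N/N=C/c1ccc(/C=C/C(=O)c2cccc(Br)c2)cc1` gives 49.7% in a functional assay on the whole organism (Ear) for inhibition, with Mus musculus as the target, with a stated time of 30 min, at a dose of 100 mg/kg by the intraperitoneal route; on this read-out lower numbers stand for less inhibition and higher numbers for more inhibition at the one dose given (going by the name of the read-out).
Compound 2 `Cc1ccc(C(=O)/C=C/c2ccc(/C=N/NC(=N)N)cc2)c(C)c1` gives 64.2% in this assay.
Compound 3 `N=C(N)N/N=C/c1ccc(/C=C/C(=O)c2ccc(Cl)cc2Cl)cc1` gives 92.5% in this assay.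

Compound 3 stands highest of the three, with both steps to it beyond the scatter: a number 42.8 percentage points higher from compound 1 to compound 3 (beyond the scatter) and a number 28.3 percentage points higher from compound 2 to compound 3 (beyond the scatter). Compound 4 `N=C(N)N/N=C/c1ccc(/C=C/C(=O)c2ccccc2Br)cc1` differs from compound 3 in one place: 2-bromophenyl in place of 2,4-dichlorophenyl on a carbonyl carbon. Among the measured compounds shown here, the steps that bear on this are the large one a number 42.8 percentage points higher from compound 1 to compound 3 (beyond the scatter) and the modest one a number 28.3 percentage points higher from compound 2 to compound 3 (beyond the scatter); a single bromine on the ring, as in compound 1, gave the lowest number of all. For compound 4 the estimated step is therefore a fall, a number 27.5 percentage points lower from compound 3 to compound 4 (beyond the scatter), likely beyond the scatter. Compound 4 is expected to give about 65%, between 42% and 88%.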

Compound 4, a percentage reported as inhibition, in the whole organism at one dose (the size of the read-out at that dose, not a potency): 78.3%
Beside the measured number, compound 4's estimate is 13.3 percentage points below it; the measured number falls inside the stated range.
By their numbers in this assay, from the lowest: compound 1; then compound 2; then compound 4; then compound 3.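

Moving the bromine alone, 2-bromophenyl in place of 3-bromophenyl on the carbonyl carbon, gives a number 28.6 percentage points higher from compound 1 to compound 4 (beyond the scatter) in this assay and so shows that a single bromine on this ring does not by itself go with a low number. 2-bromophenyl also stands clear of 2,4-dimethylphenyl with a number 14.1 percentage points higher from compound 2 to compound 4 (beyond the scatter) while a number 14.2 percentage points lower from compound 3 to compound 4 (beyond the scatter) leaves 2,4-dichlorophenyl highest of the four. Nothing measured here explains these differences. The compounds shown leave open how 2-chlorophenyl alone would compare with compound 4 and how a methoxy group or an amine on this ring would read.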